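The source may hold more compounds than are shown below. What is called first, only, known or untested is meant among the compounds shown, and "the series" means these compounds.

Measured in an ADME assay on CHO cells (Cricetulus griseus) for cytotoxicity, read by MTT assay; a higher number here means that more compound is tolerated, a lower number that less compound is tolerated:
- Compound 1 (`CN1CCN(CC2CCN(c3nccc4[nH]c(-c5ccc(F)c(Cl)c5)nc34)CC2)CC1`): 850 nM
- Compound 2 (`CN1CCN(CC2CCN(c3nccc4[nH]c(-c5ccc(F)c(C(F)(F)F)c5)nc34)CC2)CC1`): 3100 nM

Compound 2 holds the higher of the two numbers. Compound 3 (`CN1CCN(CC2CCN(c3nccc4[nH]c(-c5cccc(C(=O)N(C)C)c5)nc34)CC2)CC1`) carries 3-(dimethylcarbamoyl)phenyl in place of 4-fluoro-3-(trifluoromethyl)phenyl on an aromatic carbon. Going by the values given here, only one measured step bears on this, and only partly: trifluoromethyl in place of chloro on an aromatic carbon gave a 3.6-fold higher number from compound 1 to compound 2 (0.56 log units; beyond the scatter). Here the whole aryl group changes, so the guidance is weak. A similarly modest rise in this assay is expected, a 2.3-fold higher number from compound 2 to compound 3 (0.35 log units; beyond the scatter), although a fall cannot be excluded. For compound 3 the estimated value is 7000 nM, with an expected range of 2000 nM to 25000 nM.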

Compound 3, half-maximal cytotoxic concentration: > 50000 nM
Compound 3 ended at the assay's limit; the forecaster's own chance of this, stated with the estimate: 10%; middle value at least 7.1-fold (0.85 log units) from the limit.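

Exchanging the whole aryl group on this carbon, between two ring nitrogen atoms, changes this assay far more than the substituent swap on the ring did: there the change was a 3.6-fold higher number from compound 1 to compound 2 (0.56 log units; beyond the scatter), whereas here it is an at least 16-fold higher number from compound 2 to compound 3 (1.20 log units; beyond the scatter), and an at least 58-fold higher number from compound 1 to compound 3 (1.76 log units; beyond the scatter). Neither halogen-bearing aryl group gives a number close to that of 3-(dimethylcarbamoyl)phenyl. The value of compound 3 is a limit, not a number, so both new steps are bounds: the limit of > 50000 nM in this assay, at which 1 of the 3 values shown sits.

From the compounds shown here alone, it remains open how far compound 3 lies past that limit. Going by these compounds, it is also open whether a 3-cyanophenyl or 3-carboxyphenyl group in the same place would behave like 3-(dimethylcarbamoyl)phenyl.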